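Permeability of a Sulfone Series: Removing the Pyridone Ring

The compounds below may be only part of what the source reports. "The series", "measured", "known", "first", "only" and "open" are said of these compounds alone.

Measured in an ADME assay for permeability, using PAMPA, at pH 7.4; on this read-out higher numbers stand for higher permeability and lower numbers for lower permeability:
- compound 1 `CCCCc1nc(=O)c(S(=O)(=O)c2ccc(-c3cccnc3)cc2)c(O)n1-c1c(OC)cccc1OC`: 6 nm/s
- compound 2 `CCCCc1nc(=O)c(S(=O)(=O)c2ccc(-c3ccc(F)nc3)cc2)c(O)n1-c1c(OC)cccc1OC`: 24 nm/s
- compound 3 `CCCCc1nc(=O)c(S(=O)(=O)c2ccc(-n3ccccc3=O)cc2)c(O)n1-c1c(OC)cccc1OC`: 1 nm/s

Compound 3 stands lowest of the three numbers in this assay. The nearest is compound 1, and the step of a 6.0-fold lower number from compound 1 to compound 3 (0.78 log units; beyond the scatter) is beyond the scatter; the step of a 24-fold lower number from compound 2 to compound 3 (1.38 log units; beyond the scatter) is larger still. Compound 4 `CCCCc1nc(=O)c(S(=O)(=O)c2ccccc2)c(O)n1-c1c(OC)cccc1OC` differs from compound 3 by a hydrogen atom in place of a group of 7 heavy atoms (5 carbon, 1 nitrogen, 1 oxygen; one six-membered aromatic ring with 1 hetero atom), on an aromatic carbon, so the ring that sets compound 3 apart is taken away rather than exchanged for another ring. For the measured compounds named here, no measured step removes a ring at this place; the two that bear on it, a 6.0-fold lower number from compound 1 to compound 3 (0.78 log units; beyond the scatter) and a 24-fold lower number from compound 2 to compound 3 (1.38 log units; beyond the scatter), both show that among the three groups tried at this place the one carried by compound 3 gives the lowest number. A rise for compound 4 is therefore expected, of modest size, a 12-fold higher number from compound 3 to compound 4 (1.08 log units; beyond the scatter). The value of compound 4 in this assay is estimated at 12 nm/s, within a range from 3 nm/s to 40 nm/s.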

Compound 4, apparent permeability: 1.5 nm/s
Compound 4: middle estimate off by 8.0-fold (0.90 log units), on the high side; the whole stated range lies above it.
By their numbers in this assay, from the lowest: compounds 3 and 4 (each within the scatter of the next); then compound 1; then compound 2.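

In this assay, replacing the group of compound 3 with hydrogen stays within the scatter, a 1.5-fold higher number from compound 3 to compound 4 (0.18 log units; within the scatter), so at this place that group and hydrogen cannot be told apart. The other two groups do stand apart from hydrogen: hydrogen in place of 6-fluoropyridin-3-yl gives a 16-fold lower number from compound 2 to compound 4 (1.20 log units; beyond the scatter), and hydrogen in place of pyridin-3-yl gives a 4.0-fold lower number from compound 1 to compound 4 (0.60 log units; beyond the scatter). A ring at this place therefore does not by itself set the number, since compound 1 and compound 2 lie above compound 4 while compound 3 does not.

The data given offer no information on why these groups differ. From the compounds shown here alone, it remains open whether a small amine, a methoxy group or a carboxylic acid at this place would fall with hydrogen or with the two pyridinyl groups.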